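The source may report more compounds than this note shows. Statements on the series, on what has been measured and on what is new or still open speak of the compounds shown alone.

Measured compounds in a functional assay on LS174T cells (Homo sapiens) for inhibition, with a stated time of 4 days, tested at 10 uM; a higher number here means a stronger effect of the compound at the concentration tested, a lower number a weaker effect:
compound 1, `Fc1cccc(F)c1C#Cc1cnc2ccccc2c1`, gives 90.4%;
compound 2, `Fc1cccc(F)c1C#Cc1cc2ccccc2nc1Cl`, gives 85.1%;
compound 3, `Fc1cccc(F)c1C#Cc1cnc2ccccc2c1Cl`, gives 80.4%.

Among the compounds with values here, compound 1 holds the highest of the three numbers, though its lead over the others is small: the step of a number 5.3 percentage points lower from compound 1 to compound 2 (within the scatter) and the step of a number 10 percentage points lower from compound 1 to compound 3 (within the scatter) both lie within the scatter of this assay, so no compound can be called the more active on these numbers alone.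

Compound 4, `Fc1cccc(F)c1C#Cc1cnc2c(F)cccc2c1`, has not yet been measured. It differs from compound 1 by a single change: fluoro in place of hydrogen on an aromatic carbon. The two measured steps that bear on this are those from compound 1 to compound 2 and from compound 1 to compound 3, each a chloro in place of hydrogen on an aromatic carbon of the shared core, and each gave only a small decrease that stayed within the scatter. A fluoro in place of hydrogen on an aromatic carbon of the same core is therefore expected to leave this assay little changed, with at most a slight drop from the number of compound 1. On this basis compound 4 is expected to reach 86%, with a likely range from 72% to 96%, corresponding to an expected step of a number 4.4 percentage points lower from compound 1 to compound 4 (within the scatter).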

Compound 4, a percentage reported as inhibition, at one concentration (the size of the read-out at that concentration, not a potency): 89.1%
Estimate against measurement, compound 4: 3.1 percentage points below; low and high end bracket the measured number.
By their numbers in this assay, from the lowest: compounds 3, 2, 4 and 1 (each within the scatter of the next).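

In this assay, the change to fluoro in place of hydrogen gives a number 1.3 percentage points lower from compound 1 to compound 4 (within the scatter), so a fluoro on an aromatic carbon of a six-membered aromatic ring of carbon only, part of a fused or bridged system of two rings, ortho to a fused ring and meta to a fused ring, is tolerated at this concentration as far as the read-out can tell. The two earlier steps both concerned chloro and sat elsewhere on the shared core, so compound 4 adds two things: a first substituent on this carbon-only ring, and a first fluoro on the core itself. Nothing available explains why the read-out stays within the scatter at this position, and no measurement of any property of these compounds bears on the result.

The compounds shown leave open whether this position accepts anything larger than fluoro, such as chloro, a methoxy group, an amine or a carboxylic acid. With one concentration as the only read-out, they also leave open whether compound 1 and compound 4 would differ in effect at any other concentration.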